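This account rests on a few compounds, and the source may have more. Where it says the series, first, only, none or still open, it means among the compounds named here.

Measured so far in an ADME assay on the whole organism with Oryza sativa as the target, tested at 10 uM; on this read-out lower numbers stand for a stronger effect and higher numbers for a weaker effect at the one concentration tested:
- compound 1, `CCc1cccc(NC(=O)N[C@H](C)c2ccccc2)c1`: 36%
- compound 2, `C[C@@H](NC(=O)Nc1cccc(C(F)(F)F)c1)c1ccccc1`: 70%
- compound 3, `CCOC(=O)c1cccc(NC(=O)N[C@H](C)c2ccccc2)c1`: 88%

Compound 3 stands highest of the three numbers. Compound 2 lies nearest, a number 18 percentage points higher from compound 2 to compound 3 (beyond the scatter), and compound 1 furthest, a number 52 percentage points higher from compound 1 to compound 3 (beyond the scatter). Both gaps are beyond the scatter, so on these numbers compound 3 shows the weakest effect in this assay.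

Compound 4, `COc1cccc(NC(=O)N[C@H](C)c2ccccc2)c1`, is not yet measured. It differs from compound 3 at one place: methoxy in place of ethoxycarbonyl on an aromatic carbon. For the measured compounds named here, the steps that bear on this change are the ones that swap the group at the same place on the ring: a number 52 percentage points higher from compound 1 to compound 3 (beyond the scatter) and a number 18 percentage points higher from compound 2 to compound 3 (beyond the scatter), and further back a number 34 percentage points higher from compound 1 to compound 2 (beyond the scatter). Going by the values given here, each swap at this place so far moved the read-out beyond the scatter, so a shift beyond the scatter is expected here as well. Among the compounds with values here, no measured compound carries methoxy, so the direction can only be taken from compound 3 holding the top value with the other two well below it; a partial return toward those lower values is the working expectation. Compound 4 is therefore estimated at 58% (range 30% to 85%), meaning an expected step of a number 30 percentage points lower from compound 3 to compound 4 (beyond the scatter).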

Compound 4, a percentage reported as activity, at one concentration (the size of the read-out at that concentration, not a potency): 70%
Compound 4: middle estimate off by 12 percentage points, on the low side; measured number inside the range.
By their numbers in this assay, from the lowest: compound 1; then compounds 2 and 4 (each within the scatter of the next); then compound 3.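

In this assay, the change shows a number 18 percentage points lower from compound 3 to compound 4 (beyond the scatter), so replacing ethoxycarbonyl with methoxy lowers the number without bringing it to the level of the ethyl compound. Methoxy and trifluoromethyl cannot be separated at this place, with no change at the digits printed from compound 2 to compound 4 (within the scatter), while a number 34 percentage points higher from compound 1 to compound 4 (beyond the scatter) adds a third group that stands clearly apart from ethyl, which now gives the lowest number of the four and thus the strongest effect at the one concentration tested. No available evidence bears on what lies behind these differences.

As far as these compounds go, whether the low number belongs to ethyl alone or extends to a longer chain such as propyl remains open. Where an amine or a carboxylic acid at this place would fall relative to these four groups is also open.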